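The source may report more compounds than this note shows. Statements on the series, on what has been measured and on what is new or still open speak of the compounds shown alone.

Series notes. Among the measured compounds shown here, compound 1 `Cc1cccc(S(=O)(=O)N2CCC(N3CCC(C)CC3)CC2)c1` is the reference; in a functional assay on DLD-1 cells (Homo sapiens) for antiproliferative activity, read by CellTiter-Glo, with a stated time of 72 h (a higher number here means a weaker inhibitor, a lower number a stronger inhibitor), compound 1 gives 25 nM, the highest of the two numbers so far. Compound 2 `CC1CCN(C2CCN(S(=O)(=O)c3cccc(-c4ccccc4C(F)(F)F)c3)CC2)CC1` gives 10 nM, and the step of a 2.5-fold lower number from compound 1 to compound 2 (0.40 log units; beyond the scatter) is modest. Compound 3 `CC1CCN(C2CCN(S(=O)(=O)c3cncc(Br)c3)CC2)CC1` differs from compound 1 by 5-bromopyridin-3-yl in place of 3-methylphenyl on a sulfonyl sulfur. For the measured compounds named here, no measured step swaps the ring on the sulfonyl sulfur, so the change from compound 1 to compound 2 bears on it only loosely, as a sign that the aromatic part has so far moved the number modestly. For compound 3 a step within the scatter is expected, a 1.2-fold higher number from compound 1 to compound 3 (0.08 log units; within the scatter). Compound 3 is therefore estimated at 30 nM, within 10 nM to 90 nM.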

Compound 3, half-maximal inhibitory concentration: > 5000 nM
Compound 3: a limit, no number (the forecaster's own chance of this, stated with the estimate: 3%); middle value at least 160-fold (2.22 log units) from the limit.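

On the sulfonyl sulfur, 5-bromopyridin-3-yl in place of 3-methylphenyl gives an at least 200-fold higher number from compound 1 to compound 3 (2.30 log units; beyond the scatter), whereas the change on an aromatic carbon gave only a 2.5-fold lower number from compound 1 to compound 2 (0.40 log units; beyond the scatter). The ring on the sulfonyl sulfur can therefore move the number far more than the earlier pair indicated. The value of compound 3 is a limit of the assay, not a number: the limit of > 5000 nM in this assay, at which 1 of the 3 values shown sits.

The compounds shown do not separate the ring nitrogen from the bromine in this change. On these data alone, how a 3-bromophenyl or an unsubstituted pyridin-3-yl on the sulfonyl sulfur would read remains open.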